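The source may hold more compounds than are shown below. What is called first, only, known or untested is meant among the compounds shown, and "the series" means these compounds.

Measured compounds:
- compound 1, `Nc1nc2c(s1)-c1cccc(c1)Oc1ccc(O)cc1CCc1ccc(O)c(c1)Oc1ccc-2cc1` — 0%
- compound 2, `COc1ccc2c(c1)CCc1ccc(OC)c(c1)Oc1ccc(cc1)-c1nc(NN)sc1-c1cccc(c1)O2` — 0%

In a functional assay on KB cells (Homo sapiens) for cytotoxicity, read by MTT assay, with a stated time of 48 h, tested at 10 uM (a higher number here means more inhibition at the concentration tested (going by the name of the read-out), a lower number less inhibition), compound 1 gives 0%. Compound 2, tested the same way, gives 0%. The two values are level at the digits recorded, and the difference between them lies within the scatter of the method, so neither number is higher or lower than the other.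

The next compound, compound 3, has the structure `NNc1nc2c(s1)-c1cccc(c1)Oc1ccc(O)cc1CCc1ccc(O)c(c1)Oc1ccc-2cc1`. It differs from compound 1 in a single place: amino in place of hydrogen on a nitrogen on an aromatic ring. Everything else in the shared core of compound 1 is unchanged.

Among the measured compounds shown here, no pair of measured compounds shows this particular change, so there is no measured step to lean on. With compound 1 giving 0% and compound 2 also showing no inhibition, nothing in the data points to a rise. The step from compound 1 to compound 3 is therefore expected to be a number 2 percentage points higher from compound 1 to compound 3 (within the scatter), that is, none beyond the scatter. Compound 3 is expected to give about 2% in this assay, within a range from 0% to 12%.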

Compound 3, a percentage reported as inhibition, at one concentration (the size of the read-out at that concentration, not a potency): 51.2%
The estimate for compound 3 lay 49.2 percentage points below the measured number, and the stated range ends below it.
By their numbers in this assay, from the lowest: compounds 1 and 2 (each within the scatter of the next); then compound 3.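

In this assay, putting amino in place of hydrogen on a nitrogen on an aromatic ring gives a number 51.2 percentage points higher from compound 1 to compound 3 (beyond the scatter), a large step and the first real difference in this set. It shows that this position is sensitive: one added heavy atom, a nitrogen, turns the amino group of compound 1 into the aminoamino group of compound 3 and separates two otherwise identical structures, which the earlier level values could not reveal. This holds for this single pair on the core of compound 1, and nothing available explains why the change has so large an effect.

From the compounds shown here alone, it remains open whether a hydroxyl, a methyl or a longer chain in place of the added amino would keep, raise or lose the inhibition seen with compound 3. Going by these compounds, the figure for compound 3 also comes from a single concentration, so it is not a potency, and how the inhibition changes at other concentrations remains open too.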